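Swapping the Amide End Group: Compound 4 Before Measurement

The source may hold more compounds than are shown below. What is called first, only, known or untested is meant among the compounds shown, and "the series" means these compounds.

Measured in an assay on isolated protein (Mus musculus) for inhibition of IL15-IL15 receptor (Homo sapiens), read by resazurin assay, with stated times of 30 min and 2.5 days (a lower number here means a stronger inhibitor, a higher number a weaker inhibitor), so far:
Compound 1 `COc1ccc(NC(=O)CCCCCCCSc2nnc(Cc3nn(C)c(=O)c4ccccc34)n2C)cc1` gives 3900 nM
Compound 2 `CCCCCCCCCCSc1nnc(Cc2nn(C)c(=O)c3ccccc23)n1C` gives 7600 nM
Compound 3 `CC(C)COc1ccc(NC(=O)CCCCCCCSc2nnc(Cc3nn(C)c(=O)c4ccccc34)n2C)cc1` gives 4800 nM

Compound 3 stands second highest of the three numbers. Its nearest neighbour is compound 1, the step being a 1.2-fold higher number from compound 1 to compound 3 (0.09 log units; within the scatter), which lies within the scatter. Among the measured compounds shown here, its furthest neighbour is compound 2; no single-point step links them, so only the two values can be compared, and compound 3 at 4800 nM sits close to compound 2 at 7600 nM. The same holds for the step of a 1.9-fold higher number from compound 1 to compound 2 (0.29 log units; within the scatter), also within the scatter.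

Compound 4 `CN(C(=O)CCCCCCCSc1nnc(Cc2nn(C)c(=O)c3ccccc23)n1C)c1ccc(Cl)cc1Cl` is the next candidate. Relative to compound 3 the change is (2,4-dichlorophenyl)(methyl)amino in place of (4-(isobutoxy)phenyl)amino on a carbonyl carbon.

For the measured compounds named here, two measured steps bear on this. The step from compound 1 to compound 2 removed the whole (4-methoxyphenyl)carbamoyl end and stayed within the scatter, and the step from compound 1 to compound 3 altered the same end and likewise stayed within the scatter. Neither step involves the (2,4-dichlorophenyl)(methyl)amino group, so nothing measured points to a change beyond the scatter in this assay in either direction.

Compound 4 is therefore expected to give about 5000 nM, within a range of 2000 nM to 15000 nM. This estimate corresponds to an expected step of a 1.0-fold higher number from compound 3 to compound 4 (0.02 log units; within the scatter).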

Compound 4, half-maximal inhibitory concentration: 11900 nM
The estimate for compound 4 lay 2.4-fold (0.38 log units) below the measured number, within the range that was stated.
By their numbers in this assay, from the lowest: compounds 1, 3, 2 and 4 (each within the scatter of the next, the first and the last beyond it).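

In this assay, among the compounds shown here, this end of the chain proved sensitive for the first time: (2,4-dichlorophenyl)(methyl)amino on the carbonyl carbon gave steps beyond the scatter, both in place of (4-(isobutoxy)phenyl)amino (a 2.5-fold higher number from compound 3 to compound 4 (0.39 log units; beyond the scatter)) and in place of (4-methoxyphenyl)amino (a 3.1-fold higher number from compound 1 to compound 4 (0.48 log units; beyond the scatter)), although both steps are modest. Against the plain propyl end, the same group stays within the scatter (a 1.6-fold higher number from compound 2 to compound 4 (0.19 log units; within the scatter)), so the effect appears only relative to the two compounds that keep an aryl amide hydrogen, and the compound without an amide gives no separation from compound 4. The entering group has 0 hydrogen-bond donors and 0 hydrogen-bond acceptors where the leaving group has 1 of each, and it also brings two chlorines, but no measurement offers an explanation for the step or assigns it to any one of these differences.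

The compounds shown leave open whether the methyl on the amide nitrogen or the two chlorines carry the step, which a (2,4-dichlorophenyl)amino end or an N-methyl-(4-methoxyphenyl)amino end could separate. They also leave open how a carboxylic acid or a primary amine at this chain end would read.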